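Compound 3: 1,1-dioxothiolan-3-yl replaces 4,4-difluorocyclohexyl

The source may hold more compounds than are shown below. What is called first, only, known or untested is meant among the compounds shown, and "the series" means these compounds.

Two compounds of the series carry a number in an assay on HEK293 cells for activation of Kir3.1/Kir3.2 (Homo sapiens), read by thallium flux; a higher number here means a larger maximal response, a lower number a smaller maximal response. Compound 1 `Cc1cc(NC(=O)Cn2nnc(-c3ccccc3)n2)n(C2CCOCC2)n1` gives 115%; compound 2 `Cc1cc(NC(=O)Cn2nnc(-c3ccccc3)n2)n(C2CCC(F)(F)CC2)n1` gives 68%. Among the compounds with values here, the single measured step, a number 47 percentage points lower from compound 1 to compound 2 (beyond the scatter), comes with 4,4-difluorocyclohexyl in place of oxan-4-yl on the aromatic nitrogen. On the numbers shown compound 2 stands lowest of the two, with compound 1 the nearest and higher beyond the scatter.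

Compound 3 `Cc1cc(NC(=O)Cn2nnc(-c3ccccc3)n2)n(C2CCS(=O)(=O)C2)n1` is not yet measured. Its change from compound 2:

1,1-dioxothiolan-3-yl in place of 4,4-difluorocyclohexyl on an aromatic nitrogen

Within the data shown here, only the step of a number 47 percentage points lower from compound 1 to compound 2 (beyond the scatter) bears on this change, and it does so loosely: it also exchanged the saturated ring on the same aromatic nitrogen, and the ring that held a hetero atom, oxan-4-yl in compound 1, gave the higher value 115%. The entering 1,1-dioxothiolan-3-yl again holds a hetero atom and two hydrogen-bond acceptors, though it is five-membered, so a rise of the same size is not expected with confidence. A step of a number 22 percentage points higher from compound 2 to compound 3 (beyond the scatter) upward is expected, beyond the scatter but smaller than the measured one. Compound 3 is estimated at 90%, within 60% to 120%.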

Compound 3, largest response reached (Emax), in percent of the reference or control that the assay uses: 93%
Estimate against measurement, compound 3: 3 percentage points below; measured number inside the range.
By their numbers in this assay, from the lowest: compound 2; then compound 3; then compound 1.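

Compound 3 shows that the saturated ring on this aromatic nitrogen sets the maximal response in finer steps than the first pair could show: in this assay, a number 25 percentage points higher from compound 2 to compound 3 (beyond the scatter), yet a number 22 percentage points lower from compound 1 to compound 3 (beyond the scatter), so the three rings give three separate levels. Among these three compounds, both rings holding a hetero atom stand above the carbon-only 4,4-difluorocyclohexyl of compound 2, with no compound against that order, but 1,1-dioxothiolan-3-yl does not reach the level of oxan-4-yl in compound 1 at 115%. The last comparison changes ring size and the hetero atom together, so the two contributions cannot be separated, and nothing available explains the differences between these rings.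

Oxolan-3-yl and 1,1-dioxothian-4-yl on the same nitrogen would show whether the lower value of compound 3 relative to compound 1 follows the five-membered ring or the two oxygens on sulfur. Also open, as far as these compounds go, is how an open chain such as 2-methoxyethyl, or an amine such as piperidin-4-yl, would behave at this position.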